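The source may hold more compounds than are shown below. What is called first, only, known or untested is meant among the compounds shown, and "the series" means these compounds.

In a physicochemical assay for solubility, at pH 7.4 (a higher number here means a more soluble compound, a lower number a less soluble compound), compound 1 `CCc1ccc(NC(=O)Nc2cc(C)nc3ccccc23)cc1` gives 3300 nM and compound 3 `COc1ccc(NC(=O)Nc2cc(C)nc3ccccc23)cc1Cl` gives 400 nM. Compound 2 `Cc1cc(NC(=O)Nc2ccccc2C(C)(C)C)c2ccccc2n1` gives 100 nM, the lowest of these three numbers, and its gaps to both others lie beyond the scatter. Compound 4 `COc1ccccc1NC(=O)Nc1cc(C)nc2ccccc12` differs from compound 2 in one place: methoxy in place of tert-butyl on an aromatic carbon. Here methoxy stands in place of tert-butyl on an aromatic carbon. Within the data shown here, no measured pair differs in only one place, so no direct precedent exists for this change. A rise beyond the scatter is expected in this assay, since compound 2 at 100 nM sits at the bottom of the measured range. The expected step is a 10-fold higher number from compound 2 to compound 4 (1.00 log units; beyond the scatter). For compound 4 the estimated value is 1000 nM, with an expected range of 250 nM to 4000 nM.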

Compound 4, solubility: 100 nM
The estimate for compound 4 lay 10-fold (1.00 log units) above the measured number; the whole stated range lies above it.
By their numbers in this assay, from the lowest: compounds 2 and 4 (each within the scatter of the next); then compound 3; then compound 1.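

In this assay, methoxy in place of tert-butyl on an aromatic carbon, ortho to a large group, gives no change at the digits printed from compound 2 to compound 4 (within the scatter). Among these compounds, this is the first one-place comparison in the set, and it shows that replacing tert-butyl with methoxy, which brings in one hydrogen-bond acceptor and has fewer heavy atoms, does not move the number at this position. No measurement at hand bears on this result.

From the compounds shown here alone, whether an amine, a carboxylic acid or a longer chain at this position would also leave the number level remains open. So does whether the same change would give the same step elsewhere on this ring.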